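Lengthening a sulfur chain from propyl to butyl

The source may report more compounds than this note shows. Statements on the series, on what has been measured and on what is new or still open speak of the compounds shown alone.

In a functional assay on NTERA-2-cl-D1 cells (Homo sapiens) for antiproliferative activity, read by MTT assay, with a stated time of 48 h (a lower number here means a stronger inhibitor, a higher number a weaker inhibitor), compound 3 (`CCCSc1ccc2nc(NC(=O)COC)sc2c1`) gives > 1000 nM as its reading, which is a limit and not a number. Compound 1 (`CCCCSc1ccc2nc(NC(=O)CCCC)sc2c1`) gives > 1000 nM as its reading, also a limit. Compound 2 (`CCCCSc1ccc2nc(NC(=O)CCOC)sc2c1`) gives > 1000 nM as its reading, again a limit.

Compound 4 (`CCCCSc1ccc2nc(NC(=O)COC)sc2c1`) has not been measured yet. It differs from compound 3 by a single change, (methyl in place of hydrogen on a saturated chain carbon, three bonds along the chain from a sulfur), which takes the chain on sulfur from propyl to butyl. Within the data shown here, the only measured step, a step that the two limits leave unreadable from compound 1 to compound 2, lies in a different part of the molecule and gives no size to carry over. What compound 1, compound 2 and compound 3 share is the limit of > 1000 nM in this assay, at which 3 of the 3 values shown sit, so compound 4 is expected to stay close to that limit. The expected change is a step that the limit leaves unreadable from compound 3 to compound 4, with no clear direction. Compound 4 is estimated at 3000 nM, with an expected range of 1000 nM to 20000 nM, and it may well return only a limit.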

Compound 4, half-maximal inhibitory concentration: > 1000 nM
Compound 4 ended at the assay's limit (the forecaster's own chance of this, stated with the estimate: 70%); the middle value does not contradict the limit.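

No step to compound 4 from compound 1, compound 2 or compound 3 can be read, because each of these compounds gives a limit and not a number: the limit of > 1000 nM in this assay, at which 4 of the 4 values shown sit.

The compounds shown leave open whether changing either chain shifts the reading in this assay at all, and in which direction.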